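Hybrid of two aryl ethers: expected maximal response

The source may report more compounds than this note shows. Statements on the series, on what has been measured and on what is new or still open speak of the compounds shown alone.

Of the compounds shown here, two have been measured in an assay on HEK293 cells for positive allosteric modulation of metabotropic glutamate receptor 3 (Rattus norvegicus), read by thallium flux, with a stated time of 2.5 min; on this read-out lower numbers stand for smaller maximal responses and higher numbers for larger maximal responses. Compound 1 `Cc1c(OCCCCOc2ccc(F)c(C(=O)O)c2)ccc(C(=O)CC2CCCC2)c1C` gives 12.6%. Compound 2 `Cc1ccc(C(=O)O)cc1OCCCCOc1ccc(C(=O)CC2CCCC2)c(O)c1C` gives 26.9%, the higher of the two numbers, with compound 1 the nearest and lying beyond the usual scatter below it. Within the data shown here, no pair measured so far differs in a single place, so no single-point step is available; compound 1 and compound 2 differ both in the aryl group on the ether oxygen and in the shared core, and their two values show only that the combination found in compound 2 reaches the larger response.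

Compound 3 `Cc1c(OCCCCOc2ccc(F)c(C(=O)O)c2)ccc(C(=O)CC2CCCC2)c1O` is the next compound, still unmeasured in this assay. It differs from compound 2 at one place: 3-carboxy-4-fluorophenyl in place of 5-carboxy-2-methylphenyl on an oxygen on a saturated carbon. Among the measured compounds shown here, the aryl group entering is the one carried by compound 1, while the core of compound 3 is that of compound 2, so compound 3 is a hybrid of the two measured compounds.

With the aryl group of compound 1 attached to the core of compound 2, the maximal response of compound 3 is expected to fall between the two measured values, giving an estimated step of a number 7.9 percentage points lower from compound 2 to compound 3 (within the scatter) downward from compound 2, which may or may not exceed the scatter. For compound 3 the estimate in this assay is 19%, expected to lie between 8% and 32%.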

Compound 3, largest response reached (reported as percent of maximum), in percent of the reference or control that the assay uses: 98.4%
Estimate against measurement, compound 3: 79.4 percentage points below; the whole stated range lies below it.
By their numbers in this assay, from the lowest: compound 1; then compound 2; then compound 3.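

On the core shared by compound 2 and compound 3, with the hydroxy group in place, 3-carboxy-4-fluorophenyl in place of 5-carboxy-2-methylphenyl on the oxygen gives a number 71.5 percentage points higher from compound 2 to compound 3 (beyond the scatter) in this assay, so the aryl group at this position strongly affects the maximal response. With 3-carboxy-4-fluorophenyl held constant, hydroxy in place of methyl on an aromatic carbon gives a number 85.8 percentage points higher from compound 1 to compound 3 (beyond the scatter), so the two features that could not be separated between compound 1 and compound 2 each have a large effect here, and among the three compounds the high response occurs only where they are combined. Nothing available accounts for the size of either step or for this dependence of one change on the other.

Going by these compounds, the exchange of aryl groups alters two features at once, so it remains open whether the step follows the fluorine or the place of the carboxylic acid, which a 3-carboxyphenyl or 3-carboxy-4-methylphenyl group would help to separate. Also open, on these data alone, is whether a methoxy group or an amine in place of the hydroxy, or a longer chain between the two ether oxygens, would keep the response.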